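This account rests on a few compounds, and the source may have more. Where it says the series, first, only, none or still open, it means among the compounds named here.

Measured so far in an ADME assay on Raji cells (Homo sapiens) for cytotoxicity, read by luminescence, with a stated time of 72 h; on this read-out lower numbers stand for an effect already at smaller amounts and higher numbers for an effect only at larger amounts of compound:

Compound 1 `CCOC(=O)c1c(-c2cccc(Oc3ccccc3)c2)[nH]c2cc(OC)ccc2c1=O`: > 21500 nM, a limit of the assay
Compound 2 `CCOC(=O)c1c(-c2cccc(OC(F)(F)F)c2)[nH]c2cc(OC)ccc2c1=O`: > 21500 nM, a limit of the assay
Compound 3 `CCOC(=O)c1c(-c2cccc(Oc3ccccc3)c2)[nH]c2cc(F)cc(F)c2c1=O`: > 21500 nM, a limit of the assay

The three measured compounds share the ester-bearing core and differ in the aryl substituent or in the core itself. The change from compound 1 to compound 2 is trifluoromethyl in place of phenyl on an oxygen on an aromatic ring. Its size in this assay reads a step that the two limits leave unreadable from compound 1 to compound 2, since both ends sit at the same limit. How the core of compound 3 differs from the core of compound 1 is not broken down here.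

Compound 4 `CCOC(=O)c1c(-c2cccc(OC(F)(F)F)c2)[nH]c2cc(F)cc(F)c2c1=O` is not yet measured. It stands to compound 3 as compound 2 stands to compound 1: trifluoromethyl in place of phenyl on an oxygen on an aromatic ring. The place is the same word for word in both pairs, so this is the same change on a different core.

Expectation for compound 4 in this assay: the step is expected to be a step that the limit leaves unreadable from compound 3 to compound 4, beside the unreadable one above. Among the compounds with values here, this rests on (the limit of > 21500 nM in this assay, at which 3 of the 3 values shown sit), because the limit of > 21500 nM in this assay, at which 3 of the 3 values shown sit, gives no measured compound with a number in this assay, and the shared change has produced no readable movement. Compound 4 is therefore expected at 30000 nM, most likely reported as a limit again, with a range of 15000 nM to 100000 nM.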

Compound 4, half-maximal effective concentration: > 21500 nM
Compound 4: only a limit was reported (the forecaster's own chance of this, stated with the estimate: 85%); the middle value does not contradict the limit.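

In this assay compound 4 gives > 21500 nM, a limit of the assay. Compound 3 also stands at a limit, so no step can be read between compound 3 and compound 4: the limit of > 21500 nM in this assay, at which 4 of the 4 values shown sit. The compounds shown leave open whether any member of this series gives a numerical value in this assay, and how phenoxy and trifluoromethoxy compare on either core.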